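Swapping the Sulfonyl Amine of Compound 1

A few compounds are considered here, and "the series" means these few. Any claim that something is new, unique, unknown or untested is made for them only; others in the source may bear on it.

Compound 1, `CCOC(=O)[C@@H]1CCCN(S(=O)(=O)c2ccc(S(=O)(=O)N3CCOCC3)cc2)C1`, gives 23500 nM in a functional assay on MIA PaCa-2 cells (Homo sapiens) for inhibition, read by MTT assay, with a stated time of 7 days; on this read-out higher numbers stand for weaker inhibition and lower numbers for stronger inhibition.
Compound 2, `CCN(CC)S(=O)(=O)c1ccc(S(=O)(=O)N2CCC[C@@H](C(=O)NC)C2)cc1`, gives 8600 nM in this assay.
Compound 3, `CCN(CC)S(=O)(=O)c1ccc(S(=O)(=O)N2CCC[C@@H](C(=O)N3CCN(c4nc(C)no4)CC3)C2)cc1`, gives 250 nM in this assay.

Compound 1 has the highest number of the three, so it is the weakest inhibitor here; compound 2 sits nearest, with a lower number that is beyond the scatter, and compound 3 lies furthest, with a much lower number. Within the data shown here, the one recorded step, a 34-fold lower number from compound 2 to compound 3 (1.54 log units; beyond the scatter), changes the group on a carbonyl carbon and so tells nothing about the sulfonyl end of the molecule.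

Compound 4, `CCOC(=O)[C@@H]1CCCN(S(=O)(=O)c2ccc(S(=O)(=O)N(C)C)cc2)C1`, differs from compound 1 by dimethylamino in place of morpholin-4-yl on a sulfonyl sulfur. Among the measured compounds shown here, no measured step touches this place: compound 2 carries a diethylamino on that sulfonyl sulfur, but it also differs from compound 1 at the carbonyl, so its value cannot be credited to the amine alone. For the measured compounds named here, with no direct precedent, the expected step is a 1.2-fold lower number from compound 1 to compound 4 (0.07 log units; within the scatter), that is, nothing beyond the usual scatter. Compound 4 is therefore estimated at 20000 nM, with a range from 7000 nM to 60000 nM.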

Compound 4, half-maximal inhibitory concentration: 900 nM
The estimate for compound 4 lay 22-fold (1.35 log units) above the measured number; measured number outside the range, below it.
By their numbers in this assay, from the lowest: compound 3; then compound 4; then compound 2; then compound 1.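

The sulfonyl end of the molecule turns out not to be a silent place: dimethylamino in place of morpholin-4-yl on a sulfonyl sulfur gives a 26-fold lower number from compound 1 to compound 4 (1.42 log units; beyond the scatter) in this assay, with the rest of the molecule unchanged. Among these compounds, this is the first single-place reading at that sulfonyl sulfur, and it shows that a smaller group without a ring, 3 heavy atoms against 6, can go with a much lower number. No measurement shown explains this difference.

The ring itself and its oxygen remain unseparated, and piperidin-1-yl on the same sulfonyl sulfur would keep the ring with a carbon in place of that oxygen. On these data alone, it also remains open whether this swap would give a step of similar size in compounds with an amide on the carbonyl carbon, such as compound 2 and compound 3.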